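Naphthalene for thiophene on the cyclopentane of the urea series

This account rests on a few compounds, and the source may have more. Where it says the series, first, only, none or still open, it means among the compounds named here.

Measured so far in an assay on microsomes from intestine for inhibition of acyl-CoA:cholesterol acyltransferase (Oryctolagus cuniculus); a higher number here means a weaker inhibitor, a lower number a stronger inhibitor:
- compound 1 `CC(C)c1cccc(C(C)C)c1NC(=O)NCc1ccccc1`: 360 nM
- compound 2 `CC(C)c1cccc(C(C)C)c1NC(=O)NCC1(c2cccs2)CCCC1`: 12 nM

Compound 2 holds the lowest number of the two in this assay; the nearest is compound 1, and that gap is beyond the scatter. The next step keeps the shared core and changes only the group on the saturated ring carbon: naphthalen-1-yl in place of thiophen-2-yl on a saturated ring carbon, giving compound 3 `CC(C)c1cccc(C(C)C)c1NC(=O)NCC1(c2cccc3ccccc23)CCCC1`. Among the measured compounds shown here, no measured pair shows this change, so the step is expected to be small, a 1.2-fold lower number from compound 2 to compound 3 (0.08 log units; within the scatter), within the scatter or a slight gain. Compound 3 is estimated at 10 nM, in the range 3 nM to 40 nM.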

Compound 3, half-maximal inhibitory concentration: 34 nM
Estimate against measurement, compound 3: 3.4-fold (0.53 log units) below, within the range that was stated.
By their numbers in this assay, from the lowest: compound 2; then compound 3; then compound 1.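

In this assay, among the compounds shown here, naphthalen-1-yl in place of thiophen-2-yl on the saturated ring carbon gives a 2.8-fold higher number from compound 2 to compound 3 (0.45 log units; beyond the scatter), the first reading of a change at this position. The step is a modest loss, and compound 3 with its two six-membered aromatic rings still gives 34 nM as a strong inhibitor. No measurement to hand accounts for the step.

Open, as far as these compounds go, is how a pyridin-2-yl group on the same carbon would read against compound 2, and whether an amine or a carboxylic acid on the aromatic group is accepted there.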